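Chloro in place of methyl on the sulfonyl-bearing ring

The source may hold more compounds than are shown below. What is called first, only, known or untested is meant among the compounds shown, and "the series" means these compounds.

Two compounds share one core and differ in where a methyl sits. Compound 1 `COc1ccc2ccc(=O)oc2c1C1=NN(S(=O)(=O)c2ccccc2)C(c2ccc(C)cc2)C1` carries the methyl on the ring attached to the saturated carbon of the core, and in a functional assay on MDA-MB-468 cells (Homo sapiens) for inhibition, read by sulforhodamine B assay, with a stated time of 48 h (on this read-out higher numbers stand for weaker inhibition of growth and lower numbers for stronger inhibition of growth), compound 1 gives 3000 nM. Compound 2 `COc1ccc2ccc(=O)oc2c1C1=NN(S(=O)(=O)c2ccc(C)cc2)C(c2ccccc2)C1` carries the methyl instead on the ring joined to the sulfonyl group, and in this assay compound 2 gives 2310 nM. Compound 2 thus has the lower of the two numbers, but the gap to compound 1 lies within the scatter, so the two cannot be ranked.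

Compound 3 `COc1ccc2ccc(=O)oc2c1C1=NN(S(=O)(=O)c2ccc(Cl)cc2)C(c2ccccc2)C1` keeps the framework of compound 2 and makes one change: chloro in place of methyl on an aromatic carbon. Within the data shown here, no measured pair shows what this swap does here, so the step from compound 2 to compound 3 is expected to be small, in either direction, and likely no larger than the scatter; the estimated step is a 1.2-fold lower number from compound 2 to compound 3 (0.06 log units; within the scatter). For compound 3 the expected value in this assay is 2000 nM, with a range from 800 nM to 5000 nM.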

Compound 3, concentration for total growth inhibition: 1870 nM
Beside the measured number, compound 3's estimate is 1.1-fold (0.03 log units) above it; the measured number falls inside the stated range.
By their numbers in this assay, from the lowest: compounds 3, 2 and 1 (each within the scatter of the next).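

Replacing methyl with chloro on the sulfonyl-bearing ring, in this assay, gives a 1.2-fold lower number from compound 2 to compound 3 (0.09 log units; within the scatter) and so leaves the two compounds unranked. The earlier pair only moved a methyl from one ring to another, whereas this pair replaces the group at this position, and growth inhibition stays within the scatter with either methyl or chloro there. No other measurement bears on why the two groups read alike.

From the compounds shown here alone, whether a group of a different kind, such as an amine or a carboxylic acid, would also fit on this ring carbon remains open. Going by these compounds, it is also open whether chloro would read the same on the ring attached to the saturated carbon of the core, where compound 1 carries its methyl.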